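A few compounds are considered here, and "the series" means these few. Any claim that something is new, unique, unknown or untested is made for them only; others in the source may bear on it.

Three compounds have been measured in a physicochemical assay for lipophilicity, measured as octanol-water partition; a higher number here means a more lipophilic compound, a lower number a more polar compound:

compound 1 `COc1ccc2c(c1)[n+]([O-])c(C#N)c(-c1ccc(F)cc1)[n+]2[O-]`, 1.97
compound 2 `COc1ccc2c(c1)[n+]([O-])c(C#N)c(-c1ccc(Cl)cc1)[n+]2[O-]`, 2.09
compound 3 `COc1ccc(-c2c(C#N)[n+]([O-])c3cc(F)ccc3[n+]2[O-])cc1`, 1.97

Between compound 1 and compound 2 the change is chloro in place of fluoro on an aromatic carbon, and it gave a number 0.12 log units higher from compound 1 to compound 2 (within the scatter). Compound 3 shows the same number at the digits printed as compound 1; how the core of compound 1 and the core of compound 3 differ is not broken down here. Compound 4 `COc1ccc(-c2c(C#N)[n+]([O-])c3cc(Cl)ccc3[n+]2[O-])cc1` has not yet been measured. It carries chloro in place of fluoro on an aromatic carbon, the same kind of change as from compound 1 to compound 2, but at a different place: here on an aromatic carbon of a six-membered aromatic ring of carbon only, part of a fused or bridged system of two rings, meta to a fused ring and para to a fused ring, whereas in compound 2 the carbon is para to a large group. Among the compounds with values here, for compound 4 a step of a number 0.12 log units higher from compound 3 to compound 4 (within the scatter) is expected, because a number 0.12 log units higher from compound 1 to compound 2 (within the scatter) was the only earlier step of this kind. Compound 4 is therefore estimated at 2.09, most likely between 1.85 and 2.35.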

Compound 4, partition coefficient: 2.09
Estimate against measurement, compound 4: no gap at the digits printed; the range from low to high includes it.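

Carried to the core of compound 3, chloro in place of fluoro gave a number 0.12 log units higher from compound 3 to compound 4 (within the scatter) in this assay and matched, at the digits printed, the earlier a number 0.12 log units higher from compound 1 to compound 2 (within the scatter) on the core of compound 1, although the change now sits on an aromatic carbon of the fused system of two rings. Within the data shown here, both steps lie within the scatter, so the two pairs show only that this swap stayed within the scatter on both cores; they show no real difference within either pair and set no rule for other cores. Nothing measured here speaks to the cause of the result.

Only fluoro and chloro appear at the changed places. From the compounds shown here alone, how an amine, a carboxylic acid or a longer chain would read there in this assay remains open.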